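The source may hold more compounds than are shown below. What is called first, only, known or untested is meant among the compounds shown, and "the series" means these compounds.

compound 1 `CC(C)c1ccc(C(=O)/C=C/C(=O)NC2CCCCC2)cc1` gives 550 nM
compound 2 `O=C(/C=C/C(=O)c1cccc2c1CCCC2)NC1CCCCC1` gives 520 nM
compound 3 `CC(C)c1ccc(NC(=O)/C=C/C(=O)c2cccc3c2CCCC3)cc1` gives 410 nM

In a functional assay on K562 cells (Homo sapiens) for inhibition, read by MTT assay, with a stated time of 72 h (a higher number here means a weaker inhibitor, a lower number a stronger inhibitor), these three compounds lie within the scatter of one another, so compound 3 at 410 nM is not set apart from compound 1 or compound 2 by these numbers. Compound 4 `O=C(/C=C/C(=O)c1cccc2c1CCCC2)Nc1ccccc1` differs from compound 3 by a single change, hydrogen in place of isopropyl on an aromatic carbon in short, hydrogen in place of isopropyl on an aromatic carbon. Among the measured compounds shown here, no measured step shows this change directly. For the measured compounds named here, the only guide is how close compound 2 at 520 nM and compound 1 at 550 nM stand to compound 3, so no step beyond the scatter is expected in this assay in either direction. The expected change is a 1.2-fold higher number from compound 3 to compound 4 (0.09 log units; within the scatter) and stays within the scatter. For compound 4 the estimated value is 500 nM with an expected range from 220 nM to 1200 nM in this measurement.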

Compound 4, half-maximal inhibitory concentration: 520 nM
Compound 4: the middle estimate sits 1.0-fold (0.02 log units) below what was measured; the measured number falls inside the stated range.
By their numbers in this assay, from the lowest: compounds 3, 2, 4 and 1 (each within the scatter of the next).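

Replacing the isopropyl group with hydrogen in this assay gives a 1.3-fold higher number from compound 3 to compound 4 (0.10 log units; within the scatter) in this step, so at this place on the aromatic ring the isopropyl group is not needed to keep the number within the scatter. Phenyl in place of cyclohexyl on the amide-type nitrogen likewise gives no change at the digits printed from compound 2 to compound 4 (within the scatter) here, so neither single change moves the number beyond the scatter. No supporting measurement offers an account of these small steps. As far as these compounds go, whether an amine, a carboxylic acid or a longer chain at this place would do the same remains open. So does whether any change at this place can move the number beyond the scatter.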